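A few compounds are considered here, and "the series" means these few. Any claim that something is new, unique, unknown or untested is made for them only; others in the source may bear on it.

Three compounds have so far been measured in a functional assay on MDA-MB-231 cells (Homo sapiens) for cytotoxicity, read by MTT assay, with a stated time of 72 h; a higher number here means a weaker inhibitor, a lower number a stronger inhibitor:

compound 1, `COc1ccc(Nc2nc(SCc3ccc(C(F)(F)F)cc3)nc3ccccc23)cc1`, which gives 15700 nM;
compound 2, `COc1cc(Nc2nc(SCc3ccc(C(F)(F)F)cc3)nc3ccccc23)cc(OC)c1`, which gives 16100 nM;
compound 3, `COc1ccc(Nc2nc(SCc3ccc(C(F)(F)F)cc3)nc3ccccc23)cc1OC`, which gives 18900 nM.

The three numbers lie close together. Compound 3 sits at one end of this narrow span, but the steps reaching it are small: a 1.2-fold higher number from compound 2 to compound 3 (0.07 log units; within the scatter) and a 1.2-fold higher number from compound 1 to compound 3 (0.08 log units; within the scatter), both within the scatter of repeated measurements, so on this assay the three compounds cannot be told apart.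

Compound 4, `COc1cc(Nc2nc(SCc3ccc(C(F)(F)F)cc3)nc3ccccc23)cc(OC)c1OC`, differs from compound 3 in one place: methoxy in place of hydrogen on an aromatic carbon. Among the compounds with values here, the closest precedent is the step from compound 1 to compound 3, where a methoxy group also replaced a hydrogen on an aromatic carbon and produced a 1.2-fold higher number from compound 1 to compound 3 (0.08 log units; within the scatter). Moving methoxy groups around the same ring changed nothing either: a 1.0-fold higher number from compound 1 to compound 2 (0.01 log units; within the scatter) and a 1.2-fold higher number from compound 2 to compound 3 (0.07 log units; within the scatter). Every change tried on this ring so far has left this assay unmoved, so no step beyond the scatter is expected in either direction for compound 4.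

The expected step is therefore a 1.0-fold higher number from compound 3 to compound 4 (0.00 log units; within the scatter), essentially flat. Compound 4 is estimated at 19000 nM, with a range from 10000 nM to 38000 nM.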

Compound 4, half-maximal inhibitory concentration: > 50000 nM
Compound 4: no number, only a limit; the forecaster's own chance of this, stated with the estimate: 10%; middle value at least 2.6-fold (0.42 log units) away from the limit.
By their numbers in this assay, from the lowest: compounds 1, 2 and 3 (each within the scatter of the next). At a limit, above all of these: compound 4.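

In this assay, changes on this ring do not always leave the number flat: a methoxy group entering ortho to a methoxy group and meta to a large group brings an at least 2.6-fold higher number from compound 3 to compound 4 (0.42 log units; beyond the scatter), and the same kind of change from the other dimethoxyphenyl compound brings an at least 3.1-fold higher number from compound 2 to compound 4 (0.49 log units; beyond the scatter). So methoxy in place of hydrogen on an aromatic carbon has no single effect here, though whether the earlier and the new result truly differ cannot be settled: the same change on two cores in this assay, a 1.2-fold higher number (0.08 log units; within the scatter) from compound 1 to compound 3 and an at least 3.1-fold higher number (0.49 log units; beyond the scatter) from compound 2 to compound 4; the limit leaves it open whether they differ The reading for compound 4 is a limit and not a number: the limit of > 50000 nM in this assay, at which 1 of the 4 values shown sits.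

As far as these compounds go, how far the true value of compound 4 lies from the others stays open, so the full size of both steps is unknown. The compounds shown also leave open whether this ring position would respond the same way to a different group, such as a hydroxyl, a fluorine or an amine, and whether the pattern would hold with a nitrile in place of the trifluoromethyl group on the shared core.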